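The source may hold more compounds than are shown below. What is called first, only, known or untested is meant among the compounds shown, and "the series" means these compounds.

Among the measured compounds shown here, in a functional assay on MCF7 cells (Homo sapiens) for inhibition, read by MTT assay, with a stated time of 72 h (on this read-out lower numbers stand for stronger inhibition and higher numbers for weaker inhibition), compound 1 `CCc1ccc(NC(=O)C2CCN(C/C=C/c3ccccc3)CC2)cc1` gives 20000 nM, the highest of the three numbers so far. Compound 2 `CCCCc1ccc(NC(=O)C2CCN(C/C=C/c3ccccc3)CC2)cc1` gives 5870 nM, and compound 3 `CCCCCc1ccc(NC(=O)C2CCN(C/C=C/c3ccccc3)CC2)cc1` gives 3740 nM. Compound 4 `COc1ccccc1NC(=O)C1CCN(C/C=C/c2ccccc2)CC1` is still unmeasured. Its difference from compound 1 is 2-methoxyphenyl in place of 4-ethylphenyl on an amide-type nitrogen.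

The measured steps only lengthen the saturated chain. Both a 3.4-fold lower number from compound 1 to compound 2 (0.53 log units; beyond the scatter) and a 5.3-fold lower number from compound 1 to compound 3 (0.73 log units; beyond the scatter) are modest and beyond the scatter, while a 1.6-fold lower number from compound 2 to compound 3 (0.20 log units; within the scatter) lies within it. None of them involves a methoxy group, so they bear on this change only indirectly. The lower numbers came only with the longer chains of compound 2 and compound 3, and compound 4 has no such chain, so no gain is expected from that source. No step beyond the scatter is therefore expected in this assay, and the estimated step is a 1.1-fold lower number from compound 1 to compound 4 (0.05 log units; within the scatter). The estimate for compound 4 is 18000 nM, with an expected range of 7000 nM to 50000 nM.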

Compound 4, half-maximal inhibitory concentration: > 100000 nM
Compound 4: no number, only a limit; the forecaster's own chance of this, stated with the estimate: 15%; at least 5.5-fold (0.74 log units) between middle value and limit.
By their numbers in this assay, from the lowest: compounds 3 and 2 (each within the scatter of the next); then compound 1. At a limit, above all of these: compound 4.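

In this assay compound 4 gives > 100000 nM, which is a limit and not a number. Replacing 4-ethylphenyl with 2-methoxyphenyl on the amide-type nitrogen gives an at least 5.0-fold higher number from compound 1 to compound 4 (0.69 log units; beyond the scatter), the only step shown towards weaker inhibition, whereas the chain steps shown all run towards lower numbers or stay within the scatter. The two groups have the same heavy-atom count and differ by one hydrogen-bond acceptor, so a change of this kind at this place can cost activity with no change in that count, and the full size of the step cannot be read: the limit of > 100000 nM in this assay, at which 1 of the 4 values shown sits.

Since the change removes the ethyl group and adds the methoxy group in one step, the compounds shown do not separate the two contributions. On these data alone, whether an amine or a hydroxy group in place of the methoxy group would give a measurable number also remains open.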